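Methylsulfanyl Swap in a Series That Stays Inactive

The source may hold more compounds than are shown below. What is called first, only, known or untested is meant among the compounds shown, and "the series" means these compounds.

Three compounds share one core and differ only in the aryl group on the amide nitrogen. Compound 1 `COc1ccc(OC)c(NC(=O)c2cccc(/C=C3\CC(=O)N(c4ccccc4)C3=O)c2)c1` carries a 2,5-dimethoxyphenyl there. In an ADME assay on SW480 cells (Homo sapiens) for cytotoxicity, read by MTT assay, with a stated time of 72 h (a higher number here means a weaker inhibitor, a lower number a stronger inhibitor), compound 1 reaches only the limit of the assay, > 100000 nM. Compound 2 `O=C(Nc1ccc(F)cc1)c1cccc(/C=C2\CC(=O)N(c3ccccc3)C2=O)c1` carries a 4-fluorophenyl, and in this assay compound 2 likewise gives a limit, > 100000 nM. Compound 3 `O=C(Nc1ccc(Cl)cc1)c1cccc(/C=C2\CC(=O)N(c3ccccc3)C2=O)c1` carries a 4-chlorophenyl, and in this assay compound 3 also stands at a limit, > 100000 nM. Because all three sit at the limit of > 100000 nM in this assay, at which 3 of the 3 values shown sit, the steps a step that the two limits leave unreadable from compound 1 to compound 2, a step that the two limits leave unreadable from compound 1 to compound 3 and a step that the two limits leave unreadable from compound 2 to compound 3 cannot be sized. Compound 4 `CSc1cccc(NC(=O)c2cccc(/C=C3\CC(=O)N(c4ccccc4)C3=O)c2)c1` is the next variation: 3-(methylsulfanyl)phenyl in place of 4-chlorophenyl on an amide-type nitrogen. Among the compounds with values here, none of the measured steps yields a readable size, so nothing beyond the scatter can be expected from them, and no aryl group on the amide nitrogen has yet pulled a compound off the limit. Compound 4 is therefore expected to show a step of a number no higher from compound 3 to compound 4 (the limit leaves the size open), that is, no meaningful change. The estimate for compound 4 in this assay is 100000 nM, with a range from 30000 nM to 300000 nM, most likely reported again only as a limit.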

Compound 4, half-maximal inhibitory concentration: 74300 nM
Beside the measured number, compound 4's estimate is 1.3-fold (0.13 log units) above it; measured number inside the range.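

Among the compounds shown, compound 4 alone gives a measured number rather than a limit in this assay and shows that an aryl group on this amide nitrogen can yield a readable value. Compounds 1, 2 and 3 each remain at a limit: the limit of > 100000 nM in this assay, at which 3 of the 4 values shown sit. The readings are an at least 1.3-fold lower number from compound 3 to compound 4 (0.12 log units; that floor lies within the scatter) and an at least 1.3-fold lower number from compound 2 to compound 4 (0.12 log units; that floor lies within the scatter) and an at least 1.3-fold lower number from compound 1 to compound 4 (0.12 log units; that floor lies within the scatter) and each is only a floor, which leaves the true size of the swap open and gives no proof of a real change.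

Going by these compounds, it remains open whether the methylsulfanyl group itself or its 3-position on the ring matters, a question that 4-(methylsulfanyl)phenyl or 3-chlorophenyl on the same nitrogen could address. Also open, on these data alone, is whether an amine or a carboxylic acid on that ring would give a number at all.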